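Swapping methylsulfanyl for ethyl on a thiophene-bearing amine

This account rests on a few compounds, and the source may have more. Where it says the series, first, only, none or still open, it means among the compounds named here.

Compound 1 `C[C@H]1[C@H](NCc2ccc(C(C)(C)C)s2)C[C@H]2C[C@@H]1C2(C)C` gives 780 nM in an ADME assay on MDCK cells (Canis lupus familiaris) for cytotoxicity, read by microscopy, with a stated time of 48 h; a higher number here means that more compound is tolerated, a lower number that less compound is tolerated.
Compound 2 `CSc1ccc(CN[C@@H]2C[C@H]3C[C@@H]([C@H]2C)C3(C)C)s1` gives 25000 nM in this assay.
Compound 3 `CCCc1ccsc1CN[C@@H]1C[C@H]2C[C@@H]([C@H]1C)C2(C)C` gives 50000 nM in this assay.

All three share one core and differ only in the group on the five-membered aromatic ring. Compound 2 stands second highest of the three numbers: its nearest neighbour is compound 3, whose value differs from it only within the scatter, while compound 1 lies far below it, beyond the scatter.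

Compound 4 `CCc1ccc(CN[C@@H]2C[C@H]3C[C@@H]([C@H]2C)C3(C)C)s1` is not yet measured. It differs from compound 2 by ethyl in place of methylsulfanyl on an aromatic carbon.

Within the data shown here, only one measured step bears on this change: a 32-fold higher number from compound 1 to compound 2 (1.51 log units; beyond the scatter). There the methylsulfanyl group replaced a larger carbon-only group and the tolerated concentration rose strongly. Going from compound 2 to compound 4 reverses part of that move, since ethyl is again a carbon-only group, though a smaller one than tert-butyl. A moderate fall in the tolerated concentration is therefore expected, though compound 3, also carrying a carbon-only chain yet giving a high number, argues that any drop may stay modest.

For compound 4 the expected step is a 2.1-fold lower number from compound 2 to compound 4 (0.32 log units; beyond the scatter), giving an estimate of 12000 nM with a range from 3000 nM to 50000 nM.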

Compound 4, minimum cytotoxic concentration: 1560 nM
The estimate for compound 4 lay 7.7-fold (0.89 log units) above the measured number; measured number below the stated range.
By their numbers in this assay, from the lowest: compounds 1 and 4 (each within the scatter of the next); then compounds 2 and 3 (each within the scatter of the next).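

The result in this assay shows that this place on the ring is highly sensitive to the swap of methylsulfanyl for ethyl, even though both groups have the same count of heavy atoms (a 16-fold lower number from compound 2 to compound 4 (1.20 log units; beyond the scatter)). The earlier step from tert-butyl to methylsulfanyl could have reflected the loss of a bulky group, but ethyl is far smaller than tert-butyl by name and still does not separate from it (a 2.0-fold higher number from compound 1 to compound 4 (0.30 log units; within the scatter)). Among these three compounds, which differ only at this place, methylsulfanyl therefore stands alone in allowing a much higher concentration, while the two carbon-only groups sit together at the low end.

No measurement offered here explains why the sulfur-bearing group behaves so differently from ethyl and tert-butyl. Still open, on these data alone, is whether the high number belongs to the sulfur atom itself or to something broader, which groups such as methoxy, ethylsulfanyl or a plain methyl at the same place could help to separate.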